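Swapping Fluoro for Methyl on the Aryl Triazole

The compounds below may be only part of what the source reports. "The series", "measured", "known", "first", "only" and "open" are said of these compounds alone.

For the measured compounds named here, compound 1 (`C=C1C(=O)[C@]23C[C@@]1(O)CC[C@H]2c1ccc(O)c(C)c1[C@@H]3Cn1cc(-c2ccc(F)cc2)nn1`) is the only compound here with a numerical reading: in a functional assay on SMMC-7721 cells (Homo sapiens) for cytotoxicity, read by MTT assay, with a stated time of 4 days (on this read-out lower numbers stand for stronger inhibition and higher numbers for weaker inhibition), compound 1 gives 850 nM. Going by the values given here, compound 2 (`C=C1C[C@]23C[C@@]1(O)CC[C@@H]2c1cccc(C)c1[C@@H]3Cn1cc(-c2ccc(Cl)cc2)nn1`) differs from compound 1 in more than one place, so no single step connects the two. In this assay compound 2 gives > 20000 nM, which is a limit of the assay rather than a number; (the limit of > 20000 nM in this assay, at which 1 of the 2 values shown sits). Compound 3 (`C=C1C(=O)[C@]23C[C@@]1(O)CC[C@H]2c1ccc(O)c(C)c1[C@@H]3Cn1cc(-c2ccc(C)cc2)nn1`) has not yet been measured. It differs from compound 1 by methyl in place of fluoro on an aromatic carbon. Among the compounds with values here, no measured pair shows this kind of change, so the expectation rests on compound 1 alone, and the change is expected to shift the reading little, if at all, beyond the usual scatter. The step of a 1.2-fold higher number from compound 1 to compound 3 (0.07 log units; within the scatter) is therefore expected to be small. Compound 3 is estimated at 1000 nM, with a range from 350 nM to 3000 nM.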

Compound 3, half-maximal inhibitory concentration: 920 nM
The estimate for compound 3 lay 1.1-fold (0.04 log units) above the measured number, within the range that was stated.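

In this assay, exchanging 4-fluorophenyl for 4-methylphenyl gives a 1.1-fold higher number from compound 1 to compound 3 (0.03 log units; within the scatter), so the two compounds read alike. This is the first step shown that changes only one place, and it shows that on this aromatic carbon, para to a large group, a methyl serves as well as a fluoro in this cell read-out. Nothing shown explains why the two groups read alike.

From the compounds shown here alone, both groups are small, with one heavy atom each, so it remains open whether the reading would hold with an amine, a carboxylic acid or a longer chain on the same carbon. The chloro group of compound 2 comes with differences elsewhere in the molecule, so its own contribution cannot be read from these compounds.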